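The source may report more compounds than this note shows. Statements on the series, on what has been measured and on what is new or still open speak of the compounds shown alone.

Compound 1 `COc1cc(-c2cc(/C=C/C(=O)c3ccc(N)cc3)[nH]n2)cc(OC)c1OC` and compound 2 `COc1ccc(-c2cc(/C=C/C(=O)c3cc(OC)c(OC)c(OC)c3)[nH]n2)cc1OC` were both examined in a functional assay on K562 cells (Homo sapiens) for cytotoxicity, read by sulforhodamine B assay, with a stated time of 48 h, tested at 0.01 uM; on this read-out higher numbers stand for a weaker effect at the one concentration tested and lower numbers for a stronger effect. In this assay compound 1 gives 100%, and compound 2 gives 100%, so compound 1 sits level with compound 2 within the scatter. Compound 3 `COc1cc(-c2cc(/C=C/C(=O)c3ccc(F)c(F)c3)[nH]n2)cc(OC)c1OC` has not yet been measured in this assay; it differs from compound 1 by 3,4-difluorophenyl in place of 4-aminophenyl on a carbonyl carbon. Among the compounds with values here, no measured step between compounds is available, so the expected shift a number 3 percentage points lower from compound 1 to compound 3 (within the scatter) is estimated to stay within the scatter. Compound 3 is therefore expected to give 97%, in a range from 82% to 106%.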

Compound 3, a percentage reported as activity, at one concentration (the size of the read-out at that concentration, not a potency): 100%
For compound 3 the middle estimate is 3 percentage points below the measured one; the measured number falls inside the stated range.
By their numbers in this assay, from the lowest: compounds 1, 2 and 3 (each within the scatter of the next).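

In this assay, the carbonyl carbon takes 3,4-difluorophenyl in place of 4-aminophenyl with no change at the digits printed from compound 1 to compound 3 (within the scatter), so at this position the read-out does not separate the two aryl groups. The change removes the hydrogen-bond donor and acceptor counted for 4-aminophenyl and brings in two fluorines, yet the compounds stay level. No independent evidence bears on this result. The compounds shown leave open whether a carboxylic acid or a nitrile on this phenyl ring would move the read-out from that level.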